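Compound 4 and the Permeability of an Azetidine Amide

The compounds below may be only part of what the source reports. "The series", "measured", "known", "first", "only" and "open" are said of these compounds alone.

Measured in an ADME assay on MDCKII-LE cells (Canis lupus familiaris) for permeability; a lower number here means that the compound crosses the layer more slowly, a higher number that the compound crosses the layer faster:
- compound 1 `Cc1cnc(NC(=O)c2cc(Oc3ccc(C(=O)N(C)C)cc3)c3cc(C)oc3c2)cn1`: 5.9 10^-6 cm/s
- compound 2 `Cc1cc2c(Oc3cnc(C(=O)N4CC(C)C4)cn3)cc(C(=O)Nc3cnccn3)cc2o1`: 14.9 10^-6 cm/s
- compound 3 `Cc1cc2c(Oc3cnc(C(=O)N4CC(C)(C)C4)cn3)cc(C(=O)Nc3cnccn3)cc2o1`: 7.7 10^-6 cm/s

Compound 3, at 7.7 10^-6 cm/s, lies within the scatter of both other compounds in this assay. The next structure, compound 4 `COC1CN(C(=O)c2cnc(Oc3cc(C(=O)Nc4cnccn4)cc4oc(C)cc34)cn2)C1`, differs from it in one place, with 3-methoxyazetidin-1-yl in place of 3,3-dimethylazetidin-1-yl on a carbonyl carbon.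

Going by the values given here, only one measured step bears on this change: a 1.9-fold lower number from compound 2 to compound 3 (0.29 log units; within the scatter). It also concerns the amide's four-membered ring, where methyl replaces hydrogen on a saturated ring carbon, and it stays within the scatter. Among the compounds with values here, no measured compound carries a methoxy group on that ring, so the data give no direct measure of this exchange and no firm direction. No shift beyond the scatter is therefore expected. The expected change is a 1.0-fold lower number from compound 3 to compound 4 (0.01 log units; within the scatter). For compound 4 the estimated value is 7.5 10^-6 cm/s, with an expected range of 3.8 10^-6 cm/s to 14 10^-6 cm/s.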

Compound 4, apparent permeability: 21.8 10^-6 cm/s
Compound 4: the middle estimate sits 2.9-fold (0.46 log units) below what was measured; the whole stated range lies below it.
By their numbers in this assay, from the lowest: compounds 1, 3, 2 and 4 (each within the scatter of the next, the first and the last beyond it).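

In this assay, going by these compounds alone, the exchange on the carbonyl carbon gives a 2.8-fold higher number from compound 3 to compound 4 (0.45 log units; beyond the scatter), the first step on the four-membered ring that lies beyond the scatter, so a change at this place can move the read-out measurably. Methoxy in place of methyl gives a 1.5-fold higher number from compound 2 to compound 4 (0.17 log units; within the scatter), which stays within the scatter, so the clear step appears only in the comparison with 3,3-dimethylazetidin-1-yl. No available evidence accounts for this step, and the added hydrogen-bond acceptor in 3-methoxyazetidin-1-yl is only a count.

The compounds shown leave open how other groups on this ring, such as a hydroxy group or an amine, would compare with compound 4. They also leave open whether the same exchange would give a similar step on another core, such as that of compound 1.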